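Swapping an ethoxy for a methyl on the pyrimidine

The source may hold more compounds than are shown below. What is called first, only, known or untested is meant among the compounds shown, and "the series" means these compounds.

Of the compounds shown here, two have been measured so far. Compound 1 `CCOc1ccnc(N2CCN(c3cc(N)c4cc(OC)c(OC)cc4n3)CC2)n1` gives 0.42 nM in an assay on brain for displacement of a labelled ligand from Adrenergic receptor alpha-1 (Rattus norvegicus) (a lower number here means a stronger inhibitor, a higher number a weaker inhibitor), and compound 2 `C=CCNC(=O)N1CCN(c2cc(N)c3cc(OC)c(OC)cc3n2)CC1` gives 0.29 nM in this assay. Going by the values given here, of these two numbers compound 1 has the higher one, but the only step between them, a 1.4-fold lower number from compound 1 to compound 2 (0.16 log units; within the scatter), does not separate the pair.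

Compound 3 `COc1cc2nc(N3CCN(c4nccc(C)n4)CC3)cc(N)c2cc1OC` differs from compound 1 in one place: methyl in place of ethoxy on an aromatic carbon. Among the compounds with values here, the one measured step, a 1.4-fold lower number from compound 1 to compound 2 (0.16 log units; within the scatter), changes a different part of the molecule, so no measured step speaks directly to the ethoxy-to-methyl change on the pyrimidine. Both measured compounds sit at very low numbers despite a sizeable change on the ring nitrogen, which suggests the shared core carries most of the binding.

Compound 3 is therefore expected to land close to compound 1 in this assay, with a step of a 1.4-fold higher number from compound 1 to compound 3 (0.15 log units; within the scatter) that is not expected to exceed the scatter. The estimate for compound 3 is 0.6 nM, with a range from 0.2 nM to 1.8 nM.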

Compound 3, inhibition constant: 0.63 nM
Beside the measured number, compound 3's estimate is 1.1-fold (0.02 log units) below it; measured number inside the range.
By their numbers in this assay, from the lowest: compounds 2, 1 and 3 (each within the scatter of the next, the first and the last beyond it).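

The ethoxy-to-methyl change on the aromatic carbon next to the ring nitrogen now has a measured step of its own in this assay: a 1.5-fold higher number from compound 1 to compound 3 (0.18 log units; within the scatter). So at this position, exchanging a group of 3 heavy atoms and 1 hydrogen-bond acceptor for one of 1 heavy atom and no acceptor leaves compound 1 and compound 3 indistinguishable in this assay, which the earlier pair, changed elsewhere in the molecule, could not show. On the amine nitrogen in the ring, a 2.2-fold higher number from compound 2 to compound 3 (0.34 log units; beyond the scatter) is the first step here to pass the scatter, though only modestly, and nothing among the data shown explains either step.

The compounds shown leave open whether this tolerance extends beyond ethoxy and methyl on the pyrimidine, for instance to a hydrogen, a chlorine, an amine or a longer alkoxy chain such as butoxy. They also leave open whether the 4-methylpyrimidin-2-yl and allylcarbamoyl groups would stay this close in a compound with a different substituent on the shared core.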